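Compound 3 to compound 4: methoxy for trifluoromethyl

The source may hold more compounds than are shown below. What is called first, only, known or untested is meant among the compounds shown, and "the series" means these compounds.

In an ADME assay (liver) for metabolic stability, with Liver microsome (Homo sapiens) as the target, read by LC-MS, using microsomes, with a stated time of 30 min, tested at 4 uM (on this read-out higher numbers stand for a more stable compound and lower numbers for a less stable compound), compound 1 `COCCn1c(-c2ccccc2Cl)nc2c(N3CCN(C(C)=O)CC3)nc(C)nc21` gives 35%, compound 2 `Cc1nc(N2CCN(C)CC2)c2nc(-c3cccc(Cl)c3)n(C3CCOCC3)c2n1` gives 25% and compound 3 `Cc1nc(N2CCN(C)CC2)c2nc(-c3ccccc3C(F)(F)F)n(C3CCOCC3)c2n1` gives 24%. Compound 3 lies within the scatter of compound 2 and beyond the scatter of compound 1, whose number is the higher of that pair.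

The next compound, compound 4 `COc1ccccc1-c1nc2c(N3CCN(C)CC3)nc(C)nc2n1C1CCOCC1`, carries methoxy in place of trifluoromethyl on an aromatic carbon, ortho to a large group: methoxy in place of trifluoromethyl on an aromatic carbon. Going by the values given here, only one measured step bears on this aryl group: a number 1 percentage points lower from compound 2 to compound 3 (within the scatter), for 2-(trifluoromethyl)phenyl in place of 3-chlorophenyl. Among the compounds with values here, no measured compound carries methoxy, so that step is a weak guide. With only a number 1 percentage points lower from compound 2 to compound 3 (within the scatter) to go on, no step beyond the scatter is expected, and no direction can be argued from the data. The expected move is a number 1 percentage points lower from compound 3 to compound 4 (within the scatter), an estimate that stays within the scatter. For compound 4 the estimated value in this assay is 23%, with an expected range from 12% to 35%.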

Compound 4, percent of the compound remaining: 22%
Estimate against measurement, compound 4: 1 percentage points above; measured number inside the range.
By their numbers in this assay, from the lowest: compounds 4, 3, 2 and 1 (each within the scatter of the next, the first and the last beyond it).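

In this assay, methoxy in place of trifluoromethyl on an aromatic carbon, ortho to a large group, gives a number 2 percentage points lower from compound 3 to compound 4 (within the scatter), and the wider change of 2-methoxyphenyl in place of 3-chlorophenyl gives a number 3 percentage points lower from compound 2 to compound 4 (within the scatter). The three aryl groups on this shared core therefore stay within the scatter of one another, and the hydrogen-bond acceptor that enters with methoxy brings no separation in this read-out. No supporting measurement bears on why the number holds across these changes.

As far as these compounds go, whether a carboxylic acid or an amine on this aromatic ring would give a step beyond the scatter remains open. Compound 1 differs from compounds 2, 3 and 4 in more than one place, so its number cannot be tied to any single group.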